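Swapping Dichlorophenyl for Dimethoxyphenyl on a Shared Core

This account rests on a few compounds, and the source may have more. Where it says the series, first, only, none or still open, it means among the compounds named here.

Compound 2 `Nc1cc(N)c2nc(-c3ccccc3)c(NCc3ccc(Cl)c(Cl)c3)nc2c1`: 37200 nM
Compound 1 `CCOC(=O)[C@H](CCC(=O)O)NC(=O)c1ccc(CNc2nc3cc(N)cc(N)c3nc2-c2ccccc2)cc1`: < 100000 nM

In a functional assay on SF-295 cells (Homo sapiens) for inhibition, read by sulforhodamine B assay, with a stated time of 48 h (on this read-out lower numbers stand for stronger inhibition of growth and higher numbers for weaker inhibition of growth), compound 2 gives 37200 nM. For the measured compounds named here, compound 1 reaches only a limit of the assay, < 100000 nM, and that is the single limit among the values here (the limit of < 100000 nM in this assay, at which 1 of the 2 values shown sits). Going by the values given here, compound 2 therefore holds the only true number. Compound 3 `COc1ccc(CNc2nc3cc(N)cc(N)c3nc2-c2ccccc2)cc1OC` awaits measurement; it differs from compound 2 by 3,4-dimethoxyphenyl in place of 3,4-dichlorophenyl on a saturated chain carbon bound to a nitrogen on an aromatic ring. Among the compounds with values here, no step between two measured compounds exists to size this change, so the expectation rests on compound 2 alone: a step of a 1.3-fold higher number from compound 2 to compound 3 (0.13 log units; within the scatter) is expected, within the usual scatter. Compound 3 is thus estimated at 50000 nM, ranging from 15000 nM to 160000 nM.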

Compound 3, concentration for total growth inhibition: 28200 nM
The estimate for compound 3 lay 1.8-fold (0.25 log units) above the measured number; measured number inside the range.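

In this assay this position now has its first measured step, a 1.3-fold lower number from compound 2 to compound 3 (0.12 log units; within the scatter), which is a change too small to read. On a saturated chain carbon bound to a nitrogen on an aromatic ring, 3,4-dimethoxyphenyl and 3,4-dichlorophenyl thus cannot be told apart here, even though only the former counts 2 hydrogen-bond acceptors. Nothing measured here accounts for this likeness.

As far as these compounds go, whether a phenyl ring carrying an amine or a carboxylic acid would read differently stays open. Compound 1 gives only a limit, < 100000 nM, so its group cannot be sized.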